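A few compounds are considered here, and "the series" means these few. Any claim that something is new, unique, unknown or untested is made for them only; others in the source may bear on it.

In a functional assay on Jurkat cells (Homo sapiens) for inhibition, read by MTT assay, with a stated time of 72 h (on this read-out higher numbers stand for weaker inhibition and lower numbers for stronger inhibition), compound 1 (`C=C(Br)C(=O)Nc1cccc(/C=C/C(=O)Nc2ccccc2)c1`) gives 5000 nM and compound 2 (`C=C(Br)C(=O)Nc1cccc(/C=C/C(=O)Nc2ccc(C)cc2)c1`) gives 240 nM as the lower of the two numbers. Compound 3 (`C=C(Br)C(=O)Nc1cccc(/C=C/C(=O)Nc2ccc(SC(F)(F)F)cc2)c1`) has (trifluoromethyl)sulfanyl in place of methyl on an aromatic carbon, para to a large group ((trifluoromethyl)sulfanyl in place of methyl on an aromatic carbon). For the measured compounds named here, the only measured step bearing on this change (a 21-fold lower number from compound 1 to compound 2 (1.32 log units; beyond the scatter)) is large, but it puts methyl in place of hydrogen, so it gives no direct size for an exchange that starts from methyl. With that single step as the guide, no step beyond the scatter is expected in this assay and no firm direction can be stated, so the estimated step stays modest (a 1.3-fold higher number from compound 2 to compound 3 (0.10 log units; within the scatter)). For compound 3 the expected value is 300 nM (estimated range 80 nM to 1200 nM).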

Compound 3, half-maximal inhibitory concentration: 30100 nM
Beside the measured number, compound 3's estimate is 100-fold (2.00 log units) below it, and the stated range ends below it.
By their numbers in this assay, from the lowest: compound 2; then compound 1; then compound 3.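

In this assay this place on the aromatic carbon, para to a large group, proves able to move the number in either direction: the exchange of methyl for (trifluoromethyl)sulfanyl gives a 130-fold higher number from compound 2 to compound 3 (2.10 log units; beyond the scatter) and so more than reverses the earlier gain of a 21-fold lower number from compound 1 to compound 2 (1.32 log units; beyond the scatter) here. Set against hydrogen at the same place, the new group still gives a 6.0-fold higher number from compound 1 to compound 3 (0.78 log units; beyond the scatter) and thus leaves inhibition weaker than with no substituent at all, so a group here does not simply strengthen inhibition as methyl alone had suggested. Nothing measured here accounts for this reversal.

The compounds shown leave open whether ethyl, methoxy or chlorine at this place would follow methyl or (trifluoromethyl)sulfanyl. They also leave open whether either group would act alike on the other carbons of this six-membered aromatic ring.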